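The compounds below may be only part of what the source reports. "The series", "measured", "known", "first", "only" and "open" are said of these compounds alone.

Working notes on the series. Within the data shown here, compound 2 `CN1CCN(CCCS(=O)(=O)c2ccc3nc(NC(=O)NC(=O)c4ccccc4Cl)sc3c2)CC1` stands lowest of the three numbers so far in a physicochemical assay for lipophilicity; a higher number here means a more lipophilic compound, a lower number a more polar compound: compound 2 gives 1.8. Compound 1 `CN1CCN(CCCS(=O)(=O)c2ccc3nc(NC(=O)NC(=O)c4cc(-n5cccc5)ccc4Cl)sc3c2)CC1` gives 2.6 in this assay, and compound 3 `Cc1ccn(-c2ccc(Cl)c(C(=O)NC(=O)Nc3nc4ccc(S(=O)(=O)CCCN5CCN(C)CC5)cc4s3)c2)n1` gives 2.6. The measured steps, a number 0.80 log units lower from compound 1 to compound 2 (beyond the scatter) and a number 0.80 log units higher from compound 2 to compound 3 (beyond the scatter), both concern the substituent on the aromatic carbon of the chlorinated ring; the step of no change at the digits printed from compound 1 to compound 3 (within the scatter) is within the scatter.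

Compound 4 `CN(C)CCCS(=O)(=O)c1ccc2nc(NC(=O)NC(=O)c3ccccc3Cl)sc2c1` is the next point. The change is dimethylamino in place of 4-methylpiperazin-1-yl on a saturated chain carbon, three bonds along the chain from a sulfonyl sulfur. Among the measured compounds shown here, none of the measured steps touches the saturated chain three bonds from the sulfonyl sulfur, so nothing measured here bears directly on it; the aryl-substituent steps above say nothing about this part of the molecule. For the measured compounds named here, with no comparable step in hand, the expected step of a number 0.20 log units lower from compound 2 to compound 4 (within the scatter) is small and of uncertain direction, likely not beyond the scatter. For compound 4 the estimate in this assay is 1.6, with a range from 1 to 2.2.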

Compound 4, distribution coefficient: 1.7
Beside the measured number, compound 4's estimate is 0.10 log units below it; the measured number falls inside the stated range.
By their numbers in this assay, from the lowest: compounds 4 and 2 (each within the scatter of the next); then compounds 1 and 3 (each within the scatter of the next).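

In this assay, replacing 4-methylpiperazin-1-yl with dimethylamino on a saturated chain carbon, three bonds along the chain from a sulfonyl sulfur, gives a number 0.10 log units lower from compound 2 to compound 4 (within the scatter): the first step read at this position. Losing the six-membered ring and going from 7 heavy atoms to 3 therefore leaves the number within the scatter here, whereas a change on the aromatic carbon of the chlorinated ring gives a number 0.80 log units higher from compound 2 to compound 3 (beyond the scatter). Nothing available accounts for this small step.

Going by these compounds, whether the step stays as small with a morpholine or a carboxylic acid at the chain end, or with a longer chain, remains open. Also open, on these data alone, is whether 1H-pyrrol-1-yl and 3-methyl-1H-pyrazol-1-yl shift the number equally on the dimethylamino side chain.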